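Trading a Methoxy for a Propylsulfanyl Chain

The compounds below may be only part of what the source reports. "The series", "measured", "known", "first", "only" and "open" are said of these compounds alone.

Going by the values given here, compound 2 `COc1nc(=O)ccn1[C@@H]1O[C@H](COP(=O)(O)O)[C@@H](O)[C@H]1O` is the only member of this small set with an actual number: in an in vitro functional assay on 1321-N1 cells for agonist activity at P2Y purinoceptor 6 (Homo sapiens), read by scintillation proximity assay and inositol phosphate accumulation (a higher number here means that more compound is needed for the effect, a lower number that less compound is needed), compound 2 gives 9800 nM. Compound 1 `CCSc1nc(=O)ccn1[C@@H]1O[C@H](COP(=O)(O)O)[C@@H](O)[C@H]1O` differs from it only by an ethylsulfanyl group in place of the methoxy. In this assay compound 1 reaches only a limit of the assay, > 100000 nM. The single measured step, an at least 10-fold lower number from compound 1 to compound 2 (1.00 log units; beyond the scatter), thus runs from that limit (the limit of > 100000 nM in this assay, at which 1 of the 2 values shown sits) down to the one number shown. Compound 3 `CCCSc1nc(=O)ccn1[C@@H]1O[C@H](COP(=O)(O)O)[C@@H](O)[C@H]1O` reverses the direction of that step and goes further along the same line: propylsulfanyl in place of methoxy on an aromatic carbon. The reverse reading of an at least 10-fold lower number from compound 1 to compound 2 (1.00 log units; beyond the scatter) suggests that the number should rise again, most likely back toward the limit, and the longer chain gives no reason to expect otherwise. Compound 3 is therefore estimated to give about 100000 nM in this assay, within 30000 nM to 300000 nM. The expected step is a 10-fold higher number from compound 2 to compound 3 (1.01 log units; beyond the scatter), and quite possibly only a limit will be reported.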

Compound 3, half-maximal effective concentration: 6200 nM
Compound 3: the middle estimate sits 16-fold (1.21 log units) above what was measured; measured number below the stated range.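

In this assay, propylsulfanyl on this aromatic carbon, between two ring nitrogen atoms, does not separate from methoxy: a 1.6-fold lower number from compound 2 to compound 3 (0.20 log units; within the scatter) is the step, so a sulfur-linked chain here does not by itself rule out a measured number. The sharper contrast lies between the two sulfanyl chains, where methyl in place of hydrogen on a saturated chain carbon, two bonds along the chain from a sulfur, gives an at least 16-fold lower number from compound 1 to compound 3 (1.20 log units; beyond the scatter). The value of compound 1 is a limit and not a number: the limit of > 100000 nM in this assay, at which 1 of the 3 values shown sits.

Going by these compounds, whether a butylsulfanyl chain would keep a measured number, or whether methylsulfanyl would lose it, remains open. So does how ethoxy, propoxy or an amine at this position would compare with the three groups shown.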